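From a chloropropenyl to a hydroxypropenyl side chain

A few compounds are considered here, and "the series" means these few. Any claim that something is new, unique, unknown or untested is made for them only; others in the source may bear on it.

Three compounds have values in a functional assay on L1210 cells (Mus musculus) for inhibition (on this read-out higher numbers stand for weaker inhibition and lower numbers for stronger inhibition), so far:

Compound 1 `Nc1ccn(C/C=C/CCl)c(=O)n1` gives 50000 nM
Compound 2 `Nc1nc(O)c2ncn(C/C=C\CO)c2n1` gives 680000 nM
Compound 3 `Nc1ncnc2c1ncn2C/C=C\CCl` gives 22000 nM

Compound 1 holds the middle place of these three numbers. Compound 3 lies lower and compound 2 higher, and both gaps from compound 1 are beyond the scatter.

The next compound to be tested is compound 4 `Nc1ccn(C/C=C\CO)c(=O)n1` and it keeps the core of compound 1. The change is 3-hydroxyprop-1-en-1-yl in place of 3-chloroprop-1-en-1-yl on a saturated chain carbon bound to an aromatic nitrogen with 3-hydroxyprop-1-en-1-yl in place of 3-chloroprop-1-en-1-yl on a saturated chain carbon bound to an aromatic nitrogen.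

Among the measured compounds shown here, no measured pair shows this change alone, so any forecast is indirect. For the measured compounds named here, the one compound with a hydroxyl at the chain end is compound 2 at 680000 nM on a different core, while the chlorine-bearing compound 3 reads 22000 nM on yet another core. Three compounds cannot establish a trend, but these values lean towards a higher number for compound 4.

In this assay the estimated step of a 4.0-fold higher number from compound 1 to compound 4 (0.60 log units; beyond the scatter) points to weaker inhibition and is expected to lie beyond the scatter, though less far than the value of compound 2 would suggest.

For compound 4 the expected value is 200000 nM with an estimated range from 60000 nM to 700000 nM in this measurement.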

Compound 4, half-maximal inhibitory concentration: > 1000000 nM
Compound 4: no number, only a limit; the forecaster's own chance of this, stated with the estimate: 20%; at least 5.0-fold (0.69 log units) between middle value and limit.
By their numbers in this assay, from the lowest: compound 3; then compound 1; then compound 2. At a limit, above all of these: compound 4.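

On the core of compound 1, at the position on a saturated chain carbon bound to an aromatic nitrogen, the change from 3-chloroprop-1-en-1-yl to 3-hydroxyprop-1-en-1-yl can now be read as a single step, and in this assay it is an at least 20-fold higher number from compound 1 to compound 4 (1.30 log units; beyond the scatter). Compound 4 gives no number in this read-out, only a limit: the limit of > 1000000 nM in this assay, at which 1 of the 4 values shown sits. The step is therefore a minimum, and it shows that inhibition in this series is sensitive to the end of this side chain, even though the group that leaves and the group that enters have the same count of heavy atoms.

What the compounds shown leave open is whether chlorine is specifically needed at the chain end, or whether a bromine, an amine or a methoxy group there would keep the inhibition seen with compound 1. From the compounds shown here alone, compound 2 and compound 3 each stand without a partner that differs in one place, and whether the same change carries a step of similar size on their cores remains open.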